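Fluorine in Place of Trifluoromethyl on the Ring

The source may hold more compounds than are shown below. What is called first, only, known or untested is meant among the compounds shown, and "the series" means these compounds.

Compound 1 `COc1cc(OC)c(C(=O)/C=C/c2cccc(Cl)c2)c(O)c1CC=C(C)C` gives 59500 nM in an ADME assay on MCF7-DOX cells (Homo sapiens) for cytotoxicity, read by MTT assay, with a stated time of 48 h; a lower number here means a stronger inhibitor, a higher number a weaker inhibitor.
Compound 2 `COc1cc(OC)c(C(=O)/C=C/c2ccc(C(F)(F)F)cc2)c(O)c1CC=C(C)C` gives 73700 nM.
Compound 3 `COc1cc(OC)c(C(=O)/C=C/c2cccc(C(F)(F)F)c2)c(O)c1CC=C(C)C` gives 66600 nM.

Compound 3 has the second highest of these three numbers; its neighbours sit close by, as shown by a 1.1-fold higher number from compound 1 to compound 3 (0.05 log units; within the scatter) and a 1.1-fold lower number from compound 2 to compound 3 (0.04 log units; within the scatter). Compound 4 `COc1cc(OC)c(C(=O)/C=C/c2ccc(F)cc2)c(O)c1CC=C(C)C` is not yet measured. It differs from compound 3 in one place: 4-fluorophenyl in place of 3-(trifluoromethyl)phenyl on a double-bonded chain carbon bound to a double-bonded chain carbon. The earlier changes of this ring all stayed within the scatter: a 1.2-fold higher number from compound 1 to compound 2 (0.09 log units; within the scatter), a 1.1-fold higher number from compound 1 to compound 3 (0.05 log units; within the scatter) and a 1.1-fold lower number from compound 2 to compound 3 (0.04 log units; within the scatter). No step beyond the scatter is therefore expected here, and the expected change is a 1.0-fold lower number from compound 3 to compound 4 (0.01 log units; within the scatter). Compound 4 is estimated at 65000 nM, with a likely range from 35000 nM to 120000 nM.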

Compound 4, half-maximal inhibitory concentration: 53700 nM
Beside the measured number, compound 4's estimate is 1.2-fold (0.08 log units) above it; measured number inside the range.
By their numbers in this assay, from the lowest: compounds 4, 1, 3 and 2 (each within the scatter of the next).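

In this assay, the 4-fluorophenyl group, the smallest ring group here by heavy atoms, also stays within the scatter: a 1.2-fold lower number from compound 3 to compound 4 (0.09 log units; within the scatter), a 1.4-fold lower number from compound 2 to compound 4 (0.14 log units; within the scatter) and a 1.1-fold lower number from compound 1 to compound 4 (0.04 log units; within the scatter). On this double-bonded chain carbon, then, the 3-chlorophenyl, 3-(trifluoromethyl)phenyl, 4-(trifluoromethyl)phenyl and 4-fluorophenyl groups cannot be told apart by this read-out. No evidence is available to explain this. The compounds shown leave open whether a ring carrying an amine or a carboxylic acid would give a step beyond the scatter.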